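Series notes: methyl steps from compound 1 toward compound 4

A few compounds are considered here, and "the series" means these few. Any claim that something is new, unique, unknown or untested is made for them only; others in the source may bear on it.

Compound 1 `Cc1cc(C)c(S(C)(=O)=O)cc1C(=O)N=C(N)N` gives 11 nM in a functional assay for inhibition of sodium/hydrogen exchanger (Oryctolagus cuniculus); on this read-out higher numbers stand for weaker inhibition and lower numbers for stronger inhibition.
Compound 2 `CCc1cc(C)c(C(=O)N=C(N)N)cc1S(C)(=O)=O` gives 4.8 nM in this assay.
Compound 3 `Cc1cc(SC(C)C)c(S(C)(=O)=O)cc1C(=O)N=C(N)N` gives 12 nM in this assay.

Compound 4 `Cc1cc(SC(C)(C)C)c(S(C)(=O)=O)cc1C(=O)N=C(N)N` has not yet been measured in this assay. It is reached from compound 3 by methyl in place of hydrogen on a saturated chain carbon bound to two saturated chain carbons and a sulfur. The same kind of change occurs once among the measured compounds, from compound 1 to compound 2, as methyl in place of hydrogen on a saturated chain carbon bound to an aromatic carbon, and there it gave a 2.3-fold lower number from compound 1 to compound 2 (0.36 log units; beyond the scatter). The places are not the same: in compound 1 the change sits on a saturated chain carbon bound to an aromatic carbon, in compound 3 on a saturated chain carbon bound to two saturated chain carbons and a sulfur, so it is the same kind of change, not the same change. The cores differ as well: compound 3 is reached from compound 1 by isopropylsulfanyl in place of methyl on an aromatic carbon, which gave a 1.1-fold higher number from compound 1 to compound 3 (0.04 log units; within the scatter), while a 2.5-fold higher number from compound 2 to compound 3 (0.40 log units; beyond the scatter). Among the compounds with values here, only that single earlier step supports an expectation, and it sits at another place. For compound 4 the expected step is a 1.5-fold lower number from compound 3 to compound 4 (0.18 log units; within the scatter), somewhat smaller than the earlier one. The estimate for compound 4 in this assay is 8 nM, expected to fall between 3 nM and 20 nM.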

Compound 4, half-maximal inhibitory concentration: 22 nM
The estimate for compound 4 lay 2.8-fold (0.44 log units) below the measured number; measured number outside the range, above it.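

Carried from the core of compound 1 to the core of compound 3, the methyl step does not keep its size: the same change on two cores in this assay, a 2.3-fold lower number (0.36 log units; beyond the scatter) from compound 1 to compound 2 and a 1.8-fold higher number (0.26 log units; within the scatter) from compound 3 to compound 4, 4.2-fold (0.62 log units) apart, beyond the scatter of two such steps
The new step itself, a 1.8-fold higher number from compound 3 to compound 4 (0.26 log units; within the scatter), cannot be told from no change, so the result shows that the earlier step does not transfer as a fixed amount, not that the added methyl weakens inhibition on this core. The two places also differ, a saturated chain carbon bound to an aromatic carbon in one case and one bound to two saturated chain carbons and a sulfur in the other, so this single pair of steps cannot separate an effect of place from an effect of core.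

Putting (tert-butyl)sulfanyl in place of ethyl gives a 4.6-fold higher number from compound 2 to compound 4 (0.66 log units; beyond the scatter), and putting it in place of methyl gives a 2.0-fold higher number from compound 1 to compound 4 (0.30 log units; within the scatter), which leaves open how much of the first step belongs to the entering group and how much to the ethyl that leaves. Also open, going by these compounds, is how an amine or a carboxylic acid on that aromatic carbon would read in this assay.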